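The source may hold more compounds than are shown below. What is called first, only, known or untested is meant among the compounds shown, and "the series" means these compounds.

Compound 3 `CN1CCN(CCCOc2cccc3nc(Nc4ccc(F)c(F)c4)ccc23)CC1` gives the lowest number of the three measured in a functional assay on HT-29 cells (Homo sapiens) for inhibition, read by sulforhodamine B assay, with a stated time of 48 h (a lower number here means a stronger inhibitor of growth, a higher number a weaker inhibitor of growth), namely 620 nM. Compound 1 `CN1CCN(CCCOc2cccc3nc(Nc4ccc(Cl)c(C(F)(F)F)c4)ccc23)CC1` gives 1120 nM and compound 2 `CN1CCN(CCCOc2cccc3nc(Nc4ccc(Cl)c(F)c4)ccc23)CC1` gives 1410 nM. The step of a 1.8-fold lower number from compound 1 to compound 3 (0.26 log units; within the scatter) and the step of a 2.3-fold lower number from compound 2 to compound 3 (0.36 log units; beyond the scatter) both run toward compound 3; only the latter passes beyond the scatter. Compound 4 `CN1CCN(CCCOc2cccc3nc(Nc4cc(Cl)cc(Cl)c4)ccc23)CC1` differs from compound 3 in one place: 3,5-dichlorophenyl in place of 3,4-difluorophenyl on a nitrogen on an aromatic ring. Both earlier steps bear on this change: each put fluorine where chlorine had stood, and the new compound returns to chlorine, so part of that movement would be expected to reverse, giving a modest rise in this assay. Compound 4 is therefore expected to give 1200 nM, between 500 nM and 3000 nM, a step of a 1.9-fold higher number from compound 3 to compound 4 (0.29 log units; within the scatter).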

Compound 4, concentration for 50% growth inhibition: 1410 nM
Compound 4: the middle estimate sits 1.2-fold (0.07 log units) below what was measured; the range from low to high includes it.
By their numbers in this assay, from the lowest: compounds 3, 1, 2 and 4 (each within the scatter of the next, the first and the last beyond it).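

In this assay, replacing 3,4-difluorophenyl with 3,5-dichlorophenyl gives a 2.3-fold higher number from compound 3 to compound 4 (0.36 log units; beyond the scatter) and so separates this pair beyond the scatter. Among these compounds, the new group is not separated from the other chlorine-bearing groups, with no change at the digits printed from compound 2 to compound 4 (within the scatter) and a 1.3-fold higher number from compound 1 to compound 4 (0.10 log units; within the scatter) both within the scatter, while compound 3, the only compound without chlorine, goes against any clean split, since a 1.8-fold lower number from compound 1 to compound 3 (0.26 log units; within the scatter) also stays within it. No measurement shown here explains these differences. A 3,5-difluorophenyl or 3,4-dichlorophenyl group would separate the identity of the halogen from its placement. A methoxy group or nitrile on this ring would test whether a halogen is needed at all.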